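Sulfo in place of acetyl: notes on compound 3

This account rests on a few compounds, and the source may have more. Where it says the series, first, only, none or still open, it means among the compounds named here.

Measured in a functional assay on the whole organism with Canis familiaris (Canis lupus familiaris) as the target; on this read-out higher numbers stand for an effect only at larger amounts of compound and lower numbers for an effect already at smaller amounts:
- compound 1 `OC(CSc1[nH]cnc2ncnc1-2)CN1CCN(C(c2ccccc2)c2ccccc2)CC1`: 0.63 mg/kg
- compound 2 `CC(=O)OC(CSc1[nH]cnc2ncnc1-2)CN1CCN(C(c2ccc(F)cc2)c2ccc(F)cc2)CC1`: 0.3 mg/kg

Compound 2 holds the lower of the two numbers in this assay. At 0.3 mg/kg, compound 2 needs a smaller dose than compound 1 at 0.63 mg/kg, and this gap lies beyond the usual scatter. With only these two values, no pattern can be claimed for the series.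

The next compound is compound 3 `O=S(=O)(O)OC(CSc1[nH]cnc2ncnc1-2)CN1CCN(C(c2ccc(F)cc2)c2ccc(F)cc2)CC1`. It departs from compound 2 by one change, sulfo in place of acetyl on an oxygen on a saturated carbon.

Within the data shown here, no measured pair isolates a single change, and none shows this one, so the direction in this assay remains uncertain. A small move towards a higher number is the working expectation, with nothing beyond the scatter. The expected change is a 1.7-fold higher number from compound 2 to compound 3 (0.22 log units; within the scatter). For compound 3 the estimated dose is 0.5 mg/kg, with an expected range of 0.12 mg/kg to 2 mg/kg. Among the measured compounds shown here, the range is kept wide, as no measured step supports a narrower one.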

Compound 3, dose for half-maximal effect: 0.26 mg/kg
The estimate for compound 3 lay 1.9-fold (0.28 log units) above the measured number; the range from low to high includes it.
By their numbers in this assay, from the lowest: compounds 3 and 2 (each within the scatter of the next); then compound 1.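

In this assay, among these compounds, this is the first step that isolates a single change, and it reads a 1.2-fold lower number from compound 2 to compound 3 (0.06 log units; within the scatter). On this read-out, the oxygen on a saturated carbon therefore accepts sulfo in place of acetyl with no change beyond the scatter, even though sulfo brings a hydrogen-bond donor that acetyl lacks and a different count of heavy atoms, double bonds and acceptors. This holds for this one pair, with the rest of compound 2 kept intact, and no other measurement offers an explanation for this result.

Compound 1 differs from both compound 2 and compound 3 in more than one place, so the free hydroxyl on that carbon and the fluorine atoms on the two benzene rings cannot yet be separated as contributors to its higher number. Also open, going by these compounds, is whether this tolerance extends to other groups on the same oxygen, such as a longer acyl chain like butanoyl, a phosphono group or an acyl chain ending in a carboxylic acid.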